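Fluoro for Chloro on the Anilino Ring

This account rests on a few compounds, and the source may have more. Where it says the series, first, only, none or still open, it means among the compounds named here.

Compound 2 `N#Cc1c(Nc2ccccc2Cl)nc(SCc2cn(Cc3ccccc3Cl)nn2)nc1-c1ccccc1`: 8350 nM
Compound 1 `C#CCSc1nc(Nc2cccc(C(F)(F)F)c2)c(C#N)c(-c2ccccc2)n1`: 61100 nM

In a functional assay on B16-F10 cells (Mus musculus) for inhibition, read by MTT assay, with a stated time of 72 h (on this read-out lower numbers stand for stronger inhibition and higher numbers for weaker inhibition), compound 2 gives 8350 nM, the lowest of the two numbers; compound 1 gives 61100 nM, a gap beyond the scatter. Compound 3 `N#Cc1c(Nc2ccccc2F)nc(SCc2cn(Cc3ccccc3Cl)nn2)nc1-c1ccccc1` differs from compound 2 by fluoro in place of chloro on an aromatic carbon. For the measured compounds named here, no measured pair shows this change, so nothing here points to a direction. The step is expected to be small, near the scatter, leaning at most slightly toward a higher number: a 1.4-fold higher number from compound 2 to compound 3 (0.16 log units; within the scatter). Compound 3 is therefore estimated at 12000 nM, within 4000 nM to 40000 nM.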

Compound 3, half-maximal inhibitory concentration: 5230 nM
Estimate against measurement, compound 3: 2.3-fold (0.36 log units) above; measured number inside the range.
By their numbers in this assay, from the lowest: compounds 3 and 2 (each within the scatter of the next); then compound 1.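

In this assay, for the compounds shown here, the first measured pair for fluoro in place of chloro on this aromatic carbon gives a 1.6-fold lower number from compound 2 to compound 3 (0.20 log units; within the scatter) and thus does not separate the two groups at this position. With the rest of the structure held constant, 2-chlorophenyl and 2-fluorophenyl serve equally well within this read-out. No measured evidence bears on why the two compounds read alike. On these data alone, what a methoxy group, an amine or a trifluoromethyl group would do on this same carbon remains open. So does whether this exchange would read the same elsewhere on the ring.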